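The compounds below may be only part of what the source reports. "The series", "measured", "known", "first", "only" and "open" are said of these compounds alone.

Measured so far in an assay on isolated protein for inhibition of Amine oxidase [flavin-containing] B (Homo sapiens), read by spectrophotometry; a higher number here means a weaker inhibitor, a lower number a stronger inhibitor:
compound 1 `COc1ccccc1/C=N/Nc1nc2ccccc2nc1Cc1ccccc1` gives 790000 nM
compound 2 `COc1cc(/C(C)=N/Nc2nc3ccccc3nc2Cc2ccccc2)cc(OC)c1OC` gives 260000 nM
compound 3 `COc1ccc(/C(C)=N/Nc2nc3ccccc3nc2Cc2ccccc2)cc1` gives 280000 nM

All three numbers are very high, so all three compounds are weak inhibitors in this assay. Compound 3 stands with the second highest number of the three. Its nearest neighbour is compound 2, whose number lies within the usual scatter of that of compound 3, so nothing can be said about which of the two is stronger. Compound 1 gives a higher number than compound 3, and that gap lies beyond the scatter.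

Compound 4 `C/C(=N\Nc1nc2ccccc2nc1Cc1ccccc1)c1ccccc1` is not yet measured. It differs from compound 3 in one place: hydrogen in place of methoxy on an aromatic carbon. For the measured compounds named here, no measured pair shows exactly this change. Compound 2 and compound 3 carry different numbers of methoxy groups on that ring and still lie within the scatter of each other, which suggests that the ring substitution does not govern the number strongly here. The step from compound 3 to compound 4 is therefore expected to be small, likely none beyond the scatter, with a slight lean toward a higher number; this is the expected step of a 1.3-fold higher number from compound 3 to compound 4 (0.10 log units; within the scatter). Compound 4 is estimated to give 350000 nM, within a range from 150000 nM to 850000 nM.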

Compound 4, half-maximal inhibitory concentration: 980000 nM
For compound 4 the middle estimate is 2.8-fold (0.45 log units) below the measured one, and the stated range ends below it.
By their numbers in this assay, from the lowest: compounds 2 and 3 (each within the scatter of the next); then compounds 1 and 4 (each within the scatter of the next).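

Going from 4-methoxyphenyl to phenyl gives a 3.5-fold higher number from compound 3 to compound 4 (0.54 log units; beyond the scatter) in this assay. For the compounds shown here, this is the first change in one place whose size can be read here, and it shows that at this aromatic carbon, para to a large group, methoxy goes with a stronger inhibitor than hydrogen does, though the step is modest and both compounds remain weak inhibitors. Nothing at hand explains why the number moves.

On these data alone, it remains open whether the gain belongs to methoxy itself or would also come with another group on the same carbon, such as a hydroxyl, an amine, a chlorine or a longer chain like ethoxy. As far as these compounds go, it is also open whether any such group could bring the number down far enough to make a strong inhibitor.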